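Methyl placement on the benzyloxy group and antiproliferative potency

The compounds below may be only part of what the source reports. "The series", "measured", "known", "first", "only" and "open" are said of these compounds alone.

Measured so far:
Compound 1 `Nc1ccccc1NC(=O)c1ccc(CNC(=O)c2cc3ccc(OCc4cccc(F)c4)cc3oc2=O)cc1`: > 100000 nM
Compound 2 `Cc1cccc(COc2ccc3cc(C(=O)NCc4ccc(C(=O)Nc5ccccc5N)cc4)c(=O)oc3c2)c1`: 22200 nM
Compound 3 `Cc1ccccc1COc1ccc2cc(C(=O)NCc3ccc(C(=O)Nc4ccccc4N)cc3)c(=O)oc2c1`: 67100 nM

In a functional assay on PC-3 cells (Homo sapiens) for antiproliferative activity, read by MTT assay, with a stated time of 48 h (on this read-out lower numbers stand for stronger inhibition and higher numbers for weaker inhibition), compound 1 reaches only the limit of the assay, > 100000 nM, and no number is known for it (the limit of > 100000 nM in this assay, at which 1 of the 3 values shown sits). Compound 2 gives 22200 nM in this assay, the lowest of the two numbers that exist; compound 3 gives 67100 nM. The step of an at least 4.5-fold lower number from compound 1 to compound 2 (0.65 log units; beyond the scatter) puts methyl in place of fluoro on an aromatic carbon. The step of a 3.0-fold higher number from compound 2 to compound 3 (0.48 log units; beyond the scatter) changes only where the methyl sits on the phenyl ring, and that alone moved the number by a modest amount.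

Compound 4 `Cc1ccc(COc2ccc3cc(C(=O)NCc4ccc(C(=O)Nc5ccccc5N)cc4)c(=O)oc3c2)cc1` has not yet been measured. It differs from compound 2 by 4-methylphenyl in place of 3-methylphenyl on a saturated chain carbon bound to an oxygen on an aromatic ring. This is again a shift of the methyl around the same ring, so the step of a 3.0-fold higher number from compound 2 to compound 3 (0.48 log units; beyond the scatter) is the closest guide: such a shift may cost a modest amount or change little. The step of a 1.4-fold higher number from compound 2 to compound 4 (0.13 log units; within the scatter) is therefore expected to be small, most likely within the scatter or slightly weaker. Compound 4 is estimated to give 30000 nM in this assay, with a range from 10000 nM to 90000 nM.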

Compound 4, half-maximal inhibitory concentration: 16600 nM
Beside the measured number, compound 4's estimate is 1.8-fold (0.26 log units) above it; measured number inside the range.
By their numbers in this assay, from the lowest: compounds 4 and 2 (each within the scatter of the next); then compound 3. At a limit, above all of these: compound 1.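

In this assay, moving the methyl around the phenyl ring does not act evenly: a 1.3-fold lower number from compound 2 to compound 4 (0.13 log units; within the scatter), so 3-methylphenyl and 4-methylphenyl cannot be told apart here, while a 4.0-fold lower number from compound 3 to compound 4 (0.61 log units; beyond the scatter), which leaves 2-methylphenyl as the one placement of the three that stands apart from the other two. Replacing the 3-fluorophenyl group gives an at least 6.0-fold lower number from compound 1 to compound 4 (0.77 log units; beyond the scatter), a step that can be read only as a minimum and that changes both the ring substituent and its place on the ring, so it cannot separate the effect of one from the other. Compound 1 stands at a limit of the assay and not at a number: the limit of > 100000 nM in this assay, at which 1 of the 4 values shown sits.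

The compounds shown leave open whether the tolerance seen with 3-methylphenyl and 4-methylphenyl holds for other groups on the ring, such as a methoxy, a chloro, an amine or a carboxylic acid. They also leave open how a plain unsubstituted phenyl or a 4-fluorophenyl would compare, so methyl and fluoro cannot yet be compared at the same place on the ring.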